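Swapping acetyl for butoxy on the aryl ring

The source may report more compounds than this note shows. Statements on the series, on what has been measured and on what is new or still open speak of the compounds shown alone.

Measured so far:
compound 1, `COc1ccc2cc(/C=C3\CCCN=C3c3cccnc3)ccc2c1`, 600 nM
compound 2, `CC(=O)c1ccc(/C=C2\CCCN=C2c2cccnc2)cc1`, 4490 nM
compound 3, `Oc1cccc(/C=C2\CCCN=C2c2cccnc2)c1`, 1170 nM

These three compounds share a core and differ in the aromatic group hanging off it. In an assay on membranes from brain for displacement of a labelled ligand from Neuronal acetylcholine receptor; alpha4/beta2 (Rattus norvegicus), with a stated time of 3 h (a lower number here means a stronger inhibitor, a higher number a weaker inhibitor), compound 1 gives 600 nM, compound 3 gives 1170 nM, and compound 2 gives 4490 nM, the highest of the three numbers and therefore the weakest binder among them; its gap to compound 3 and to compound 1 lies beyond the scatter in each case.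

Compound 4, `CCCCOc1ccc(/C=C2\CCCN=C2c2cccnc2)cc1`, has not yet been measured. It differs from compound 2 as follows: butoxy in place of acetyl on an aromatic carbon. For the measured compounds named here, no pair of measured compounds shows this exact exchange, so the size of the step is uncertain. Since compound 1, which also carries an alkoxy group, gives 600 nM, a moderate move toward a lower number is expected, a step of a 2.2-fold lower number from compound 2 to compound 4 (0.35 log units; beyond the scatter). For compound 4 the expected value in this assay is 2000 nM, within a range from 600 nM to 6500 nM.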

Compound 4, inhibition constant: 1960 nM
Compound 4: middle estimate off by 1.0-fold (0.01 log units), on the high side, and the stated range covers the measured number.
By their numbers in this assay, from the lowest: compounds 1, 3 and 4 (each within the scatter of the next, the first and the last beyond it); then compound 2.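

In this assay, placing butoxy instead of acetyl on this aromatic carbon, para to a large group, gives a 2.3-fold lower number from compound 2 to compound 4 (0.36 log units; beyond the scatter). For the compounds shown here, this is the first direct reading of a single change at this position, and the step is modest but beyond the scatter. The two groups have the same counts of hydrogen-bond donors and acceptors and neither carries a net charge, yet butoxy has more heavy atoms, so this position accepts the larger group with no loss of binding; nothing available explains the shift.

A single exchange cannot separate the effect of removing acetyl from that of adding butoxy. An ethoxy group, a longer hexyloxy chain or an amine on the same carbon would show how far the trend extends.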